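The source may hold more compounds than are shown below. What is called first, only, known or untested is meant among the compounds shown, and "the series" means these compounds.

Working notes on the series. In a functional assay on L5178Y cells (Mus musculus) for cytotoxicity, read by MTT assay (on this read-out higher numbers stand for weaker inhibition and lower numbers for stronger inhibition), compound 1 (`CC(=O)c1ccc(OCCCCN2CCN(c3cccnc3)CC2)cc1`) gives 69 nM, which lies within the scatter of compound 3 (`CCC(=O)c1ccc(OCCCN2CCN(c3cnccn3)CC2)cc1`) at 47.5 nM, whereas compound 2 (`CCC(C)(C)c1ccc(OCCCCN2CCN(c3cccnc3)CC2)cc1`) gives 9.23 nM. Compound 4 (`CC(=O)c1ccc(OCCCCN2CCN(c3ncccn3)CC2)cc1`) has not been measured yet. It departs from compound 1 in one place, with pyrimidin-2-yl in place of pyridin-3-yl on an amine nitrogen in a ring.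

Among the compounds with values here, the only measured single-place step, a 7.5-fold lower number from compound 1 to compound 2 (0.87 log units; beyond the scatter), swaps acetyl for 1,1-dimethylpropyl, so it leaves this amine nitrogen untouched and gives no direct guide. Compound 3 carries a different aromatic ring on that nitrogen but also differs from compound 1 elsewhere, so the value of compound 3, 47.5 nM, is only weak support for expecting no large shift. No step beyond the scatter is therefore expected in this assay. The expected change is a 1.3-fold lower number from compound 1 to compound 4 (0.10 log units; within the scatter). For compound 4 the estimated value is 55 nM, with an expected range of 20 nM to 150 nM.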

Compound 4, half-maximal inhibitory concentration: > 100 nM
Compound 4: a limit, no number; the forecaster's own chance of this, stated with the estimate: 3%; middle value at least 1.8-fold (0.25 log units) from the limit.
By their numbers in this assay, from the lowest: compound 2; then compounds 3 and 1 (each within the scatter of the next). At a limit, above all of these: compound 4.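

Within the data shown here, this is the first reading at the amine nitrogen, as the earlier single-place step changed only the group on an aromatic carbon. In this assay compound 4 reads as a limit, not a number: the limit of > 100 nM in this assay, at which 1 of the 4 values shown sits.

Pyrimidin-2-yl in place of pyridin-3-yl gives an at least 1.4-fold higher number from compound 1 to compound 4 (0.16 log units; that floor lies within the scatter), so the change brings no lower number here, but the floor alone does not separate the two compounds beyond the scatter, and the true size of the step cannot be read.

The compounds shown leave open how a phenyl or pyridin-2-yl group on this nitrogen would read. They also leave open whether pyrimidin-2-yl would give the same result with 1,1-dimethylpropyl in place of acetyl.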